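The source may hold more compounds than are shown below. What is called first, only, known or untested is meant among the compounds shown, and "the series" means these compounds.

Compound 1 `Cc1ccc(N2CCN(Cn3nc(-c4ccc5c(c4)OCCO5)oc3=S)CC2)c(C)c1` gives > 50000 nM in a functional assay on SW 1116 cells (Homo sapiens) for antiproliferative activity, read by MTT assay, with a stated time of 48 h (on this read-out lower numbers stand for stronger inhibition and higher numbers for weaker inhibition), which is a limit of the assay and not a number.
Compound 2 `Fc1ccc(N2CCN(Cn3nc(-c4ccc5c(c4)OCCO5)oc3=S)CC2)cc1` gives > 50000 nM in this assay, again a limit of the assay.

Compound 2 therefore stands at the limit, with no number of its own. The step that the two limits leave unreadable from compound 1 to compound 2 cannot be read, because both of its ends sit at the limit of > 50000 nM in this assay, at which 2 of the 2 values shown sit.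

Compound 3 `S=c1oc(-c2ccc3c(c2)OCCO3)nn1CN1CCN(c2ccccn2)CC1` differs from compound 2 by pyridin-2-yl in place of 4-fluorophenyl on an amine nitrogen in a ring. Going by the values given here, the only measured step that touches the group on this ring nitrogen is the one from compound 1 to compound 2, and its size is not readable, so it gives no direction for this assay; it shows only that two different groups at this place both left the compound at the limit. Compound 3 is expected to stay close to that limit, an estimated step of a number no higher from compound 2 to compound 3 (the limit leaves the size open). The estimate for compound 3 is 50000 nM, between 20000 nM and 100000 nM.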

Compound 3, half-maximal inhibitory concentration: 9490 nM
The estimate for compound 3 lay 5.3-fold (0.72 log units) above the measured number; the whole stated range lies above it.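

The group on this ring nitrogen can change the result in this assay: pyridin-2-yl gives an at least 5.2-fold lower number from compound 2 to compound 3 (0.72 log units; beyond the scatter), and it gives an at least 5.2-fold lower number from compound 1 to compound 3 (0.72 log units; beyond the scatter). Compound 3 is thus the only compound shown with a measured number rather than a limit, and so the first to show that this place can move the read-out. Compound 1 and compound 2 each remain at a limit of the assay, so the step between them still cannot be read: the limit of > 50000 nM in this assay, at which 2 of the 3 values shown sit.

The compounds shown leave open whether the lower number goes with the ring nitrogen of pyridin-2-yl, with where that nitrogen sits, or simply with the loss of the substituted phenyl rings. Plain phenyl, pyridin-4-yl or pyrimidin-2-yl on the same ring nitrogen would help to separate these possibilities.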